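The source may hold more compounds than are shown below. What is called first, only, known or untested is meant among the compounds shown, and "the series" means these compounds.

Compound 1, `COc1ccc(NC(=O)C(=O)c2cn(C(C)(C)COCC(=O)O)c3ccccc23)cn1`, is the starting point. In a functional assay on FaDu cells (Homo sapiens) for cytotoxicity, read by MTT assay, with a stated time of 72 h (a higher number here means that more compound is tolerated, a lower number that less compound is tolerated), compound 1 gives only a limit, > 10000 nM, and not a number. Compound 2, `COc1ccc(NC(=O)C(=O)c2cn(C(C)C)c3cnccc23)cn1`, is the other measured compound, and in this assay compound 2 likewise reaches only a limit, > 10000 nM. The measurements so far thus show (the limit of > 10000 nM in this assay, at which 2 of the 2 values shown sit), so compound 1 stands where every value shown stands, and nothing here separates it from compound 2. Compound 3, `COCC(C)n1cc(C(=O)C(=O)Nc2ccc(OC)nc2)c2ccccc21`, differs from compound 1 in one place: a group of 5 heavy atoms (4 carbon, 1 oxygen; no ring) in place of a group of 9 heavy atoms (6 carbon, 3 oxygen; no ring), on an aromatic nitrogen. For the measured compounds named here, no step between measured compounds is available to set a size for such a change, so the expectation for this assay is no step beyond the scatter, most likely again a limit. Compound 3 is therefore estimated at 12000 nM, with a range from 5000 nM to 30000 nM. That estimate is expected to mean a step that the limit leaves unreadable from compound 1 to compound 3.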

Compound 3, concentration lethal to 50% of the cells in the FaDu assay: 12 nM
Compound 3: middle estimate off by 1000-fold (3.00 log units), on the high side, and the stated range ends above it.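

For the compounds shown here, in the FaDu assay the exchange on the aromatic nitrogen gives an at least 830-fold lower number from compound 1 to compound 3 (2.92 log units; beyond the scatter), the first step that can be read. In the FaDu assay compound 1 had shown only a limit and no number, > 10000 nM. In the FaDu assay compound 2 had likewise shown only a limit and no number, > 10000 nM. The values shown gather at that limit: the limit of > 10000 nM in the FaDu assay, at which 2 of the 3 values shown sit. This position therefore matters on the shared core: with 1-(methoxymethyl)ethyl in place of the group of 9 heavy atoms, the read-out moves from that limit to a measured number, and the lower number means that less compound is tolerated.

In a physicochemical assay for solubility, in phosphate buffer, at pH 7.4 (a higher number here means a more soluble compound, a lower number a less soluble compound), compound 1 gives only a limit, <= 200000 nM. In the physicochemical assay compound 3 gives 40000 nM. The step in the physicochemical assay cannot be read, since compound 1 has only a limit there: the limit of <= 200000 nM in the physicochemical assay, at which 1 of the 2 values shown sits. Also open, on these data alone, is which part of the exchanged group carries the step in the FaDu assay, and whether an amine or a chain ending in a hydroxyl group on this nitrogen would give a similar number.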